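A few compounds are considered here, and "the series" means these few. Any claim that something is new, unique, unknown or untested is made for them only; others in the source may bear on it.

Measured so far:
- compound 1, `O=C(N/N=C/c1cn(Cc2cc(-c3ccccc3)cnc2Cl)nn1)c1ccc(F)cc1`: 152 ug/mL
- compound 2, `Cc1cnc(Cl)c(Cn2cc(/C=N/NC(=O)c3ccc(C(F)(F)F)cc3)nn2)c1`: 258 ug/mL

In an ADME assay on RAW264.7 cells (Mus musculus) for cytotoxicity, read by MTT assay, with a stated time of 72 h (on this read-out lower numbers stand for stronger inhibition and higher numbers for weaker inhibition), compound 2 gives 258 ug/mL, and compound 1 gives 152 ug/mL; the two values lie within the scatter of each other, so neither is separated from the other on this read-out.

Compound 3, `O=C(N/N=C/c1cn(Cc2cc(-c3ccccc3)cnc2Cl)nn1)c1ccc(C(F)(F)F)cc1`, is not yet measured. It differs from compound 2 by phenyl in place of methyl on an aromatic carbon. Within the data shown here, no measured step between any two compounds is available here, so the expectation rests only on compounds 1 and 2 sitting close together despite differing at two places. The expected step of a 1.3-fold lower number from compound 2 to compound 3 (0.11 log units; within the scatter) is small, if anything a modest fall, not clearly beyond the scatter. Compound 3 is expected to give 200 ug/mL, with a range from 90 ug/mL to 400 ug/mL.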

Compound 3, half-maximal inhibitory concentration: 313 ug/mL
Beside the measured number, compound 3's estimate is 1.6-fold (0.19 log units) below it; the range from low to high includes it.
By their numbers in this assay, from the lowest: compounds 1, 2 and 3 (each within the scatter of the next, the first and the last beyond it).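

In this assay, phenyl in place of methyl on an aromatic carbon, para to a chloro group, gives a 1.2-fold higher number from compound 2 to compound 3 (0.08 log units; within the scatter), so this position takes the six-carbon aromatic ring without a separable shift in the read-out. Trifluoromethyl in place of fluoro on an aromatic carbon gives a 2.1-fold higher number from compound 1 to compound 3 (0.31 log units; beyond the scatter), a modest step and the only one here beyond the scatter. No measurement at hand bears on the cause of either step. From the compounds shown here alone, whether an amine or a carboxylic acid on the same aromatic carbon would separate from methyl and phenyl remains open.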